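The source may report more compounds than this note shows. Statements on the series, on what has been measured and on what is new or still open speak of the compounds shown alone.

Measured compounds:
Compound 1, `COc1ccc([C@@H]2C/C(=N\O)c3c(O)cc(OCc4cn(CC5CC5)nn4)cc3O2)cc1O`: 6320 nM
Compound 2, `COc1ccc([C@@H]2CC(=O)c3c(O)cc(OCc4cn(Cc5ccc(C)cc5)nn4)cc3O2)cc1O`: 16800 nM
Compound 3, `CCn1cc(COc2cc(O)c3c(c2)O[C@H](c2ccc(OC)c(O)c2)C/C3=N\O)nn1`: 3140 nM

In a functional assay on RAW264.7 cells (Mus musculus) for inhibition, read by Griess assay, with stated times of 2 h and 24 h (a lower number here means a stronger inhibitor, a higher number a weaker inhibitor), compound 2 gives the highest of the three numbers; compound 1 stands nearest to it, and compound 3 furthest, both gaps lying beyond the scatter. The unmeasured compound 4, `CCCn1cc(COc2cc(O)c3c(c2)O[C@H](c2ccc(OC)c(O)c2)CC3=O)nn1`, is reached from compound 2 by a change at the saturated chain carbon bound to an aromatic nitrogen: ethyl in place of 4-methylphenyl on a saturated chain carbon bound to an aromatic nitrogen.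

For the measured compounds named here, only one measured step touches the same place. It runs a 2.0-fold lower number from compound 1 to compound 3 (0.30 log units; within the scatter), and it also replaces a larger group with a smaller one on that chain carbon. Going by the values given here, compound 2 differs from compounds 1 and 3 in more than one place, so no single step links it to either; its values show only that compound 2 sits well above both. Among the compounds with values here, the one step at this position points to a modest fall in the number when the group shrinks, and the change from compound 2 to compound 4 removes a much larger group. Compound 4 is therefore expected to give a somewhat lower number than compound 2, by about a 2.6-fold lower number from compound 2 to compound 4 (0.41 log units; beyond the scatter), with the estimate for compound 4 in this assay put at 6500 nM, within a range of 2500 nM to 15000 nM.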

Compound 4, half-maximal inhibitory concentration: 9670 nM
Beside the measured number, compound 4's estimate is 1.5-fold (0.17 log units) below it; the range from low to high includes it.
By their numbers in this assay, from the lowest: compounds 3, 1, 4 and 2 (each within the scatter of the next, the first and the last beyond it).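

In this assay the exchange of 4-methylbenzyl for propyl gives a 1.7-fold lower number from compound 2 to compound 4 (0.24 log units; within the scatter) and so takes a six-membered aromatic ring of carbon only away from the saturated chain carbon bound to an aromatic nitrogen, with no shift that stands clear of the scatter. For the compounds shown here, the only earlier step at this place, a 2.0-fold lower number from compound 1 to compound 3 (0.30 log units; within the scatter), exchanged cyclopropyl for methyl, whereas here 7 heavy atoms leave and 2 enter, so a much larger exchange reads the same way on a second pair of compounds, and neither pair goes against this. The data offer no measurement that would explain why the number stays within the scatter at this place.

Going by these compounds, whether an amine, a carboxylic acid or a longer chain such as hexyl on that saturated chain carbon would move the number beyond the scatter remains open. Also open is whether 4-methylbenzyl on the core of compound 3 would read the same as the ethyl group there, and so whether the wide gaps among these compounds belong to this place at all or to the other place in which they differ.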